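The source may hold more compounds than are shown below. What is called first, only, known or untested is meant among the compounds shown, and "the series" means these compounds.

Compound 1 `CC(C)c1ccc(-c2nc(N)c3cc(Cc4ccccc4)sc3n2)o1` gives 283 nM in a functional assay on CHO-K1 cells for antagonist activity at adenosine receptor A1 (Homo sapiens), read by a beta-galactosidase reporter and cAMP accumulation, with stated times of 15 min and 6 h; on this read-out higher numbers stand for weaker inhibition and lower numbers for stronger inhibition.
Compound 2 `Cn1cnc(-c2nc(N)c3cc(Cc4ccccc4)sc3n2)c1` gives 2330 nM in this assay.
Compound 3 `COc1cccc(-c2nc(N)c3cc(Cc4ccccc4)sc3n2)c1` gives 266 nM in this assay.

Among these three, compound 3 has the lowest number, but compound 1 sits so close that the two cannot be told apart: a 1.1-fold lower number from compound 1 to compound 3 (0.03 log units; within the scatter). Only compound 2 clearly stands apart, as an 8.8-fold lower number from compound 2 to compound 3 (0.94 log units; beyond the scatter) shows.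

Compound 4 `Nc1nc(-c2ccncc2)nc2sc(Cc3ccccc3)cc12` keeps the shared core and changes only the group on the aromatic carbon between the two ring nitrogen atoms: pyridin-4-yl in place of 3-methoxyphenyl on an aromatic carbon.

Within the data shown here, two measured steps bear on this. Swapping the 5-isopropylfuran-2-yl group of compound 1 for a 3-methoxyphenyl group changed little, a 1.1-fold lower number from compound 1 to compound 3 (0.03 log units; within the scatter), whereas putting a 1-methyl-1H-imidazol-4-yl group in that place cost a good deal, an 8.2-fold higher number from compound 1 to compound 2 (0.92 log units; beyond the scatter). A pyridin-4-yl group resembles neither case closely, so the expectation is a modest rise in the number, somewhere short of what compound 2 showed: the estimated step is a 2.6-fold higher number from compound 3 to compound 4 (0.42 log units; beyond the scatter). Compound 4 is therefore expected to give about 700 nM in this assay, with a plausible range from 200 nM to 2500 nM.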

Compound 4, inhibition constant: 812 nM
Beside the measured number, compound 4's estimate is 1.2-fold (0.06 log units) below it; measured number inside the range.
By their numbers in this assay, from the lowest: compounds 3 and 1 (each within the scatter of the next); then compound 4; then compound 2.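

Changing the carbon-only six-membered aromatic ring of compound 3 to a six-membered aromatic ring with one nitrogen is enough to move the number in this assay (a 3.1-fold higher number from compound 3 to compound 4 (0.48 log units; beyond the scatter)). Among these compounds, compound 4 also adds a level that the earlier compounds did not show. It sits clearly apart from both ends of the series, on one side from the imidazole (a 2.9-fold lower number from compound 2 to compound 4 (0.46 log units; beyond the scatter)) and on the other from the furan (a 2.9-fold higher number from compound 1 to compound 4 (0.46 log units; beyond the scatter)), so this position gives more than one low pair and one high outlier. Among these four compounds, the two groups with a ring nitrogen give the higher numbers, with compounds 1 and 3 lower and indistinguishable, but no measurement here explains this shift.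

The compounds shown leave open whether the rise follows from having a ring nitrogen at all or from where it sits in the ring, a question that a pyridin-3-yl or pyridin-2-yl group would address. They also leave open how much the methoxy group of compound 3 contributes, which an unsubstituted phenyl group would help to separate from the ring itself.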